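The source may report more compounds than this note shows. Statements on the series, on what has been measured and on what is new or still open speak of the compounds shown alone.

Compound 1, `COc1cc2c(Oc3ccc(NC(=O)c4cn(-c5ccccc5F)nn4)cc3F)ccnc2cc1OCCCN1CCN(C)CC1`, sets the reference point for this series. In a functional assay on MKN-45 cells (Homo sapiens) for cytotoxicity, read by MTT assay, with a stated time of 72 h (on this read-out higher numbers stand for weaker inhibition and lower numbers for stronger inhibition), compound 1 gives 140 nM. Compound 2, `COc1cc2c(Oc3ccc(NC(=O)c4cn(-c5c(C)cccc5C)nn4)cc3F)ccnc2cc1OCCCN1CCN(C)CC1`, carries a 2,6-dimethylphenyl on the aromatic nitrogen of the triazole in place of the 2-fluorophenyl of compound 1, but in this assay compound 2 gives "not determined" (no result reported), so compound 2 stands without a number: there is nothing to place it above or below compound 1.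

Compound 3, `COc1cc2c(Oc3ccc(NC(=O)c4cn(-c5ccc(F)c(F)c5)nn4)cc3F)ccnc2cc1OCCCN1CCN(C)CC1`, is the next step from compound 2. The change is 3,4-difluorophenyl in place of 2,6-dimethylphenyl on an aromatic nitrogen; the rest of the shared core, the amide, the fluorinated aryl ether and the side chain, is untouched.

Within the data shown here, since compound 2 has no value, no measured step leads into compound 3, and the size of the change in this assay cannot be read from a neighbour. Among the measured compounds shown here, the only anchor is compound 1 at 140 nM, which also carries a fluorinated phenyl on the same nitrogen. On that basis compound 3 is expected to land near compound 1, at an estimated 150 nM, with a range from 40 nM to 550 nM.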

Compound 3, half-maximal inhibitory concentration: 160 nM
Compound 3: the middle estimate sits 1.1-fold (0.03 log units) below what was measured, and the stated range covers the measured number.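

In this assay, among these compounds, the exchange of 2-fluorophenyl for 3,4-difluorophenyl on the aromatic nitrogen amounts to a 1.1-fold higher number from compound 1 to compound 3 (0.06 log units; within the scatter) and is the first measured change at this position, showing that a second fluorine on the phenyl ring, placed as in 3,4-difluorophenyl, leaves the read-out where it was within the scatter of repeated measurements. The step from compound 2 to compound 3 cannot be read, so what the 2,6-dimethylphenyl does at this position remains unplaced, and the two numbers available both belong to fluorinated phenyl groups. No measurement offered here speaks to what lies behind this flat result.

The compounds shown leave open whether this level depends on fluorine at all, since an unsubstituted phenyl, a methoxyphenyl or a nitrile-bearing phenyl on the same nitrogen has no number here. They also leave open how far the position tolerates a departure from the aryl groups, for instance a benzyl, a cyclohexyl or a short alkyl chain carrying an amine, in this assay.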